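Replacing carboxy with carbamoyl in compound 2

The source may report more compounds than this note shows. Statements on the series, on what has been measured and on what is new or still open speak of the compounds shown alone.

Values measured in a functional assay on P388 cells (Mus musculus) for antiproliferative activity; a lower number here means a stronger inhibitor, a higher number a weaker inhibitor
Compound 1 `COc1ccc(S(=O)(=O)Nc2cccc3c(C#N)c[nH]c23)cc1` gives 0.17 ug/mL
Compound 2 `N#Cc1c[nH]c2c(NS(=O)(=O)c3ccc(C(=O)O)cc3)cccc12` gives > 100 ug/mL

Compound 2 stands at > 100 ug/mL in this assay, and this is a limit of the assay and not a number.

Compound 3 `N#Cc1c[nH]c2c(NS(=O)(=O)c3ccc(C(N)=O)cc3)cccc12` differs from compound 2 in one place: amino in place of hydroxy on a carbonyl carbon. Put simply, this change turns carboxy into carbamoyl.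

Within the data shown here, only one measured step bears on this change, and it involves the same carboxy group. That step, an at least 580-fold higher number from compound 1 to compound 2 (2.76 log units; beyond the scatter), is large and lies well beyond the scatter, and it came with carboxy in place of methoxy on an aromatic carbon. Compound 3 no longer carries carboxy, so part of that loss may return, although a single step cannot show how much. A large move towards a lower number is therefore expected, but compound 3 is expected to remain a weaker inhibitor than compound 1, which gives 0.17 ug/mL in this assay.

The expected change is an at least 33-fold lower number from compound 2 to compound 3 (1.52 log units; beyond the scatter), and it is expected to lie beyond the scatter. For compound 3 the estimate is 3 ug/mL, with an expected range of 0.3 ug/mL to 30 ug/mL.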

Compound 3, half-maximal inhibitory concentration: 2.5 ug/mL
Estimate against measurement, compound 3: 1.2-fold (0.08 log units) above; low and high end bracket the measured number.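

In this assay compound 2 gives > 100 ug/mL and that value is a limit of the assay and not a number: the limit of > 100 ug/mL in this assay, at which 1 of the 3 values shown sits. Even measured against that limit, swapping a single atom on the carbonyl carbon, amino in place of hydroxy, gives an at least 40-fold lower number from compound 2 to compound 3 (1.60 log units; beyond the scatter) and shows that the large loss seen with carboxy does not follow from the carbonyl alone, which compound 3 keeps. The recovery is only partial, as carbamoyl in place of methoxy on the aromatic carbon still leaves a 15-fold higher number from compound 1 to compound 3 (1.17 log units; beyond the scatter) and so methoxy, carbamoyl and carboxy each give a clearly different result at this one carbon.

Three compounds cannot show whether the remaining gap to compound 1 comes with the carbonyl or with the amino group, and they give no general rule for this position. On these data alone, a methyl ester, a dimethylamide or a plain methyl group at the same carbon would help separate these possibilities, and how any of them would fare stays open.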